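The source may report more compounds than this note shows. Statements on the series, on what has been measured and on what is new or still open speak of the compounds shown alone.

Measured so far:
compound 1 `COc1cccc([C@@H](CO)O[C@H]2CCCN(Cc3ccc(C(=O)O)cc3C)[C@H]2c2ccccc2)c1`, 81000 nM
compound 2 `OC[C@@H](O[C@H]1CCCN(Cc2ncc[nH]2)[C@H]1c1ccccc1)c1cc(Cl)cc(Cl)c1`, 47000 nM
compound 3 `CC(=O)NS(=O)(=O)c1ccc(CN2CCC[C@H](O[C@H](CO)c3cc(Cl)cc(Cl)c3)[C@@H]2c2ccccc2)cc1`, 14000 nM

In an assay on isolated protein for activation of cGMP-dependent protein kinase 1 (Homo sapiens), read by ADP-Glo, with stated times of 30 min and 2 h, in the presence of a further agent that is not named here (on this read-out lower numbers stand for an effect already at smaller amounts and higher numbers for an effect only at larger amounts of compound), compound 2 stands second highest of the three numbers; compound 1 lies within the scatter of it, while compound 3 gives a number beyond the scatter below it. Compound 4 `Cc1nc(C(=O)O)ccc1CN1CCC[C@H](O[C@H](CO)c2cc(Cl)cc(Cl)c2)[C@@H]1c1ccccc1` is not yet measured. It differs from compound 2 by a group of 10 heavy atoms (7 carbon, 1 nitrogen, 2 oxygen; one six-membered aromatic ring with 1 hetero atom) in place of a group of 5 heavy atoms (3 carbon, 2 nitrogen; one five-membered aromatic ring with 2 hetero atoms), on a saturated chain carbon bound to an amine nitrogen in a ring. Among the compounds with values here, no measured pair isolates this change. Compound 3, which carries an acidic group on the same position and gives 14000 nM, suggests that such groups are tolerated; compound 1, with a different aryl, gives 81000 nM. Compound 4 is therefore expected to lie at 20000 nM, range 6000 nM to 60000 nM. The expected step is a 2.4-fold lower number from compound 2 to compound 4 (0.37 log units; beyond the scatter), toward lower numbers, of modest size.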

Compound 4, half-maximal effective concentration: 370 nM
Estimate against measurement, compound 4: 54-fold (1.73 log units) above; the measured number lies below the stated range.
By their numbers in this assay, from the lowest: compound 4; then compound 3; then compounds 2 and 1 (each within the scatter of the next).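

In this assay, within the data shown here, the group on the saturated chain carbon bound to an amine nitrogen in a ring can strongly shift the read-out: the entering group gives a 130-fold lower number from compound 2 to compound 4 (2.10 log units; beyond the scatter) and is the first change here with so large a step. At this same place, compound 3 gives 14000 nM and compound 4 gives 370 nM on the same core, so the two entering groups are not interchangeable. No supporting data bear on the origin of this step. As far as these compounds go, it remains open which part of the entering group carries the step. A methyl ester or a primary amide in place of the carboxylic acid would test that part.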